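Chloro for Bromo on Two Related Cores

The source may hold more compounds than are shown below. What is called first, only, known or untested is meant among the compounds shown, and "the series" means these compounds.

Compound 1 `CC(C)Nc1nc2cc(-c3ccc(Br)cc3)sc2c(=O)[nH]1` and compound 3 `CC(C)Nc1nc2c(-c3ccc(Br)cc3)csc2c(=O)[nH]1` are built from the same atoms joined differently; the difference between the two cores is not broken down here. In an ADME assay on HepG2 cells (Homo sapiens) for cytotoxicity, read by MTT assay, with a stated time of 72 h (on this read-out lower numbers stand for higher toxicity in this test and higher numbers for lower toxicity in this test), compound 1 gives 13400 nM, while compound 3 gives 6500 nM. Compound 2 `CC(C)Nc1nc2cc(-c3ccc(Cl)cc3)sc2c(=O)[nH]1` carries chloro in place of bromo on an aromatic carbon. In this assay compound 2 reaches only the assay limit of > 15600 nM, a limit of > 15600 nM in this assay, at which 1 of the 3 values shown sits, rather than a number. The measured change an at least 1.1-fold higher number from compound 1 to compound 2 (0.06 log units; that floor lies within the scatter) therefore sets only a floor. Compound 4 `CC(C)Nc1nc2c(-c3ccc(Cl)cc3)csc2c(=O)[nH]1` applies the same change to the core of compound 3, namely (chloro in place of bromo on an aromatic carbon). Because the measured step of an at least 1.1-fold higher number from compound 1 to compound 2 (0.06 log units; that floor lies within the scatter) gives only a floor, the step from compound 3 to compound 4 is expected to be a 1.2-fold higher number from compound 3 to compound 4 (0.09 log units; within the scatter). Compound 4 is thus estimated at 8000 nM, between 4000 nM and 16000 nM.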

Compound 4, half-maximal cytotoxic concentration: 7100 nM
Beside the measured number, compound 4's estimate is 1.1-fold (0.05 log units) above it; the range from low to high includes it.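

On the second core, chloro in place of bromo gives a 1.1-fold higher number from compound 3 to compound 4 (0.04 log units; within the scatter), so in this assay the swap makes no change that stands out from the usual scatter there. The value of compound 2, > 15600 nM, is a limit of the assay and not a number. Two cores cannot establish a rule, and they do not show that the change has the same size on both: the same change on two cores in this assay, an at least 1.1-fold higher number (0.06 log units; that floor lies within the scatter) from compound 1 to compound 2 and a 1.1-fold higher number (0.04 log units; within the scatter) from compound 3 to compound 4; the limit leaves it open whether they differ

The compounds shown leave open how a group other than a halogen, such as an amine or a carboxylic acid, would read in the same place on the aromatic ring. They also leave open whether a longer chain on the ring would read differently on either core.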